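Series notes: benzyl removal at the aromatic oxygen

The source may report more compounds than this note shows. Statements on the series, on what has been measured and on what is new or still open speak of the compounds shown alone.

Measured so far:
- compound 1 `CS(=O)(=O)OCC1CN(S(C)(=O)=O)c2cc(OCc3ccccc3)ccc21` — 4.39 ug/mL
- compound 2 `CS(=O)(=O)N1CC(CCl)c2ccc(OCc3ccccc3)cc21` — 6.32 ug/mL

Both compounds were read in a functional assay on KB cells (Homo sapiens), read by crystal violet staining; a higher number here means a weaker inhibitor, a lower number a stronger inhibitor. Going by the values given here, compound 2 has the highest number of the two, but its nearest neighbour compound 1 sits within the scatter of it; the one measured step, a 1.4-fold higher number from compound 1 to compound 2 (0.16 log units; within the scatter), is itself within the scatter, so no ordering between the two is established.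

Compound 3 `CS(=O)(=O)N1CC(CCl)c2ccc(O)cc21` is not yet measured. It differs from compound 2 by hydrogen in place of benzyl on an oxygen on an aromatic ring. Among the compounds with values here, the only step in hand, a 1.4-fold higher number from compound 1 to compound 2 (0.16 log units; within the scatter), concerns the group on the saturated chain carbon, not the aromatic oxygen, so it does not bear on this change and the series gives no direct precedent for it. There is no basis from the measured pair to expect a particular direction; a step of any size beyond the scatter is possible and cannot be ruled in or out from these data.

Compound 3 is estimated at 14 ug/mL in this assay, with a broad range from 4 ug/mL to 55 ug/mL, which corresponds to an expected step of a 2.2-fold higher number from compound 2 to compound 3 (0.35 log units; beyond the scatter).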

Compound 3, half-maximal inhibitory concentration: 4.24 ug/mL
Beside the measured number, compound 3's estimate is 3.3-fold (0.52 log units) above it; the measured number falls inside the stated range.
By their numbers in this assay, from the lowest: compounds 3, 1 and 2 (each within the scatter of the next).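

Within this assay hydrogen in place of benzyl on an oxygen on an aromatic ring gives a 1.5-fold lower number from compound 2 to compound 3 (0.17 log units; within the scatter) and this is the first measured step at this position. Benzyl, with its 7 heavy atoms and its aromatic ring, can therefore leave the oxygen with no step beyond the scatter, so on the shared core with the chloro group the benzyl is not required to hold the number in this range. Nothing in hand gives a reason for this result.

From the compounds shown here alone, the pair spans only the two ends of a size range at this oxygen, so it remains open whether methyl, a longer chain, a chain ending in an amine or one ending in a carboxylic acid would stay within the scatter or move beyond it. It is also open whether hydrogen on this oxygen would give the same kind of step with (methylsulfonyl)oxy on the saturated chain carbon in place of chloro, since the compounds shown pair that group only with benzyl.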